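Cytotoxicity Limits and an Expected Bromophenyl Analogue

The source may hold more compounds than are shown below. What is called first, only, known or untested is meant among the compounds shown, and "the series" means these compounds.

Compound 1 `Cc1ccccc1COc1ccc2c(c1)[C@@H](O)CN(C)C2` was tested in an ADME assay on Vero cells (Chlorocebus sabaeus) for cytotoxicity, read by sulforhodamine B assay, with a stated time of 72 h; a higher number here means a weaker inhibitor, a lower number a stronger inhibitor. Compound 1 gives > 100000 nM, which is a limit of the assay and not a number. Compound 2 `CN1Cc2ccc(OCCCn3cnc([N+](=O)[O-])c3)cc2[C@@H](O)C1` also gives a limit in this assay, > 50000 nM. Compound 1 therefore stands at the limit of > 100000 nM in this assay, at which 1 of the 2 values shown sits. Compound 3 `CN1Cc2ccc(OCc3cccc(Br)c3)cc2[C@@H](O)C1` carries 3-bromophenyl in place of 2-methylphenyl on a saturated chain carbon bound to an oxygen on an aromatic ring, that is, 3-bromophenyl in place of 2-methylphenyl on a saturated chain carbon bound to an oxygen on an aromatic ring. Going by the values given here, no measured step is available. The step of a number no higher from compound 1 to compound 3 (the limit leaves the size open) is expected to stay within the scatter, with compound 3 most likely reported again as a limit. Compound 3 is estimated at 100000 nM, between 30000 nM and 300000 nM.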

Compound 3, half-maximal inhibitory concentration: 60300 nM
Compound 3: middle estimate off by 1.7-fold (0.22 log units), on the high side; the measured number falls inside the stated range.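

Compound 3 is the first of the compounds shown to give a number rather than a limit in this assay, and 3-bromophenyl in place of 2-methylphenyl on a saturated chain carbon bound to an oxygen on an aromatic ring gives an at least 1.6-fold lower number from compound 1 to compound 3 (0.21 log units; that floor lies within the scatter). This floor does not separate the two compounds, and the full size of the step cannot be read, since compound 1 gives only a limit: the limit of > 100000 nM in this assay, at which 1 of the 3 values shown sits.

The compounds shown leave open whether 2-bromophenyl or 3-methylphenyl at this place would give a number. They also leave open how a carboxylic acid or an amine on the phenyl ring would read.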